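This account rests on a few compounds, and the source may have more. Where it says the series, first, only, none or still open, it means among the compounds named here.

Notes on the series. In a functional assay on L1210 cells (Mus musculus) for antiproliferative activity, with a stated time of 72 h (on this read-out lower numbers stand for an effect already at smaller amounts and higher numbers for an effect only at larger amounts of compound), compound 1 `Cc1cn([C@@H]2O[C@H](CO)[C@@H](CN)[C@H]2O)c(=O)[nH]c1=O` gives > 100 uM, which is a limit and not a number. Compound 2 `Cc1cn([C@@H]2O[C@H](CO)[C@@H](CO)[C@H]2O)c(=O)[nH]c1=O` gives > 100 uM, again a limit and not a number. The record so far is the limit of > 100 uM in this assay, at which 2 of the 2 values shown sit. Compound 2 therefore has no numerical position in the series.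

Compound 3 `Cc1cn([C@@H]2O[C@H](CO)[C@@H](CN=[N+]=[N-])[C@H]2O)c(=O)[nH]c1=O` carries azido in place of hydroxy on a saturated chain carbon bound to a saturated ring carbon. Within the data shown here, the only measured step bearing on this change is a step that the two limits leave unreadable from compound 1 to compound 2, and it offers no size to carry over. In this assay no step beyond the scatter is expected, and no direction can be assigned. The expected step is a step that the limit leaves unreadable from compound 2 to compound 3. For compound 3 the estimate is 150 uM, with an expected range of 50 uM to 400 uM.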

Compound 3, concentration for half-maximal effect: > 100 uM
Compound 3: no number, only a limit (the forecaster's own chance of this, stated with the estimate: 85%); the middle value is on the limit's open side.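

No step can be read among compound 1, compound 2 and compound 3, since each gives a limit and not a number: the limit of > 100 uM in this assay, at which 3 of the 3 values shown sit. The compounds shown leave open at what concentration, if any, any of the three reaches half-maximal effect in this assay.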